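Allyl in Place of Methyl on the Sulfur of Compound 1

The compounds below may be only part of what the source reports. "The series", "measured", "known", "first", "only" and "open" are said of these compounds alone.

Measured so far:
- Compound 1, `CSc1nc(NCc2ccc(-c3ccccn3)cc2)c2[nH]nc(C(C)C)c2n1`, gives 783 nM in a functional assay on HT cells (Homo sapiens) for antiproliferative activity, read by fluorescence, with a stated time of 72 h; a higher number here means a weaker inhibitor of growth, a lower number a stronger inhibitor of growth.
- Compound 2, `CC(C)c1n[nH]c2c(NCc3ccc(-c4ccccn4)cc3)nc(SCC(C)(C)N)nc12`, gives 85 nM.
- Compound 3, `CC(C)c1n[nH]c2c(NCc3ccc(-c4ccccn4)cc3)nc(SCCC(N)=O)nc12`, gives 120 nM.

Compound 1 has the highest number of the three in this assay; compound 3 is its nearest neighbour and compound 2 its furthest. Both known steps leave compound 1 at the same place, a saturated chain carbon bound to a sulfur: a 9.2-fold lower number from compound 1 to compound 2 (0.96 log units; beyond the scatter) and a 6.5-fold lower number from compound 1 to compound 3 (0.81 log units; beyond the scatter). Between the two extended compounds the gap is small: a 1.4-fold higher number from compound 2 to compound 3 (0.15 log units; within the scatter).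

Compound 4, `C=CCSc1nc(NCc2ccc(-c3ccccn3)cc2)c2[nH]nc(C(C)C)c2n1`, differs from compound 1 thus: vinyl in place of hydrogen on a saturated chain carbon bound to a sulfur. The steps to compound 2 and compound 3 bear on it in that they too grow the chain on this sulfur, but the group entering here is vinyl, not the 1-amino-1-methylethyl of compound 2 nor the carbamoylmethyl of compound 3, so those gains mark an upper bound rather than a forecast. A smaller step in the same direction is expected: a 1.7-fold lower number from compound 1 to compound 4 (0.24 log units; within the scatter). Compound 4 is accordingly estimated at 450 nM, in the range 180 nM to 1100 nM.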

Compound 4, concentration for 50% growth inhibition: 1010 nM
Beside the measured number, compound 4's estimate is 2.2-fold (0.35 log units) below it; the range from low to high includes it.
By their numbers in this assay, from the lowest: compounds 2 and 3 (each within the scatter of the next); then compounds 1 and 4 (each within the scatter of the next).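

In this assay, the step from methyl to allyl on the sulfur is a 1.3-fold higher number from compound 1 to compound 4 (0.11 log units; within the scatter) and so gives no sign that added chain carbons alone change the number. Against compound 4, the two other groups on the same saturated chain carbon stand apart, with an 8.4-fold higher number from compound 3 to compound 4 (0.93 log units; beyond the scatter) for carbamoylmethyl and a 12-fold higher number from compound 2 to compound 4 (1.07 log units; beyond the scatter) for 1-amino-1-methylethyl, so the gains in compound 2 and compound 3 go with those particular groups and not with chain growth as such. No measurement shown here explains this difference between the groups.

From the compounds shown here alone, it remains open whether a saturated propyl chain reads like allyl. Going by these compounds, it is also open whether a plain 2-aminoethyl chain, or a carboxylic acid at the chain end, falls with compound 2 and compound 3 or with compound 1 and compound 4.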